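Dihydropyridine series: removing the dimethoxymethyl group

The compounds below may be only part of what the source reports. "The series", "measured", "known", "first", "only" and "open" are said of these compounds alone.

Compounds measured so far in an assay on IMR-32 cells for inhibition of Voltage-dependent N-type calcium channel subunit alpha-1B (Homo sapiens), with a stated time of 5 min; on this read-out higher numbers stand for weaker inhibition and lower numbers for stronger inhibition:
compound 1, `COC(OC)C1=C(C(=O)OC/C=C/c2ccccc2)C(c2cc(Cl)cc(Cl)c2)C(C(=O)O)=CN1`, 1000 nM
compound 2, `COC(OC)C1=C(C(=O)OC/C=C/c2ccccc2)C(c2ccc(Cl)c(Cl)c2)C(C(=O)O)=CN1`, 520 nM
compound 3, `COC(OC)C1=C(C(=O)OC/C=C/c2ccccc2)C(c2cccc(C(F)(F)F)c2)C(C(=O)O)=CN1`, 1100 nM

Compound 3 gives the highest number of the three. Its gap to compound 1 is within the scatter, so the two cannot be ordered; against compound 2 the step of a 2.1-fold higher number from compound 2 to compound 3 (0.33 log units; beyond the scatter) is beyond the scatter, if modest. The other two steps, a 1.9-fold lower number from compound 1 to compound 2 (0.28 log units; within the scatter) and a 1.1-fold higher number from compound 1 to compound 3 (0.04 log units; within the scatter), are within the scatter. All three steps change only the aryl group on the saturated ring carbon of the shared core.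

Compound 4, `O=C(O)C1=CNC=C(C(=O)OC/C=C/c2ccccc2)C1c1cccc(C(F)(F)F)c1`, is not yet measured. It differs from compound 3 in one place: hydrogen in place of dimethoxymethyl on a double-bonded ring carbon. Within the data shown here, no measured step bears on this change; every step so far leaves the dimethoxymethyl group in place, and nothing shows how the core behaves without it. The aryl group of compound 4 is the same as in compound 3, so the value of compound 3 is the only anchor.

Among the measured compounds shown here, with no step to guide direction, compound 4 is expected to give about the same number as compound 3, a step of no change at the digits printed from compound 3 to compound 4 (within the scatter), with a wide range to reflect the lack of any bearing step. The estimate for compound 4 in this assay is 1100 nM, between 300 nM and 4000 nM.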

Compound 4, half-maximal inhibitory concentration: 1200 nM
The estimate for compound 4 lay 1.1-fold (0.04 log units) below the measured number; low and high end bracket the measured number.
By their numbers in this assay, from the lowest: compounds 2, 1, 3 and 4 (each within the scatter of the next, the first and the last beyond it).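

In this assay, the step at this position, a 1.1-fold higher number from compound 3 to compound 4 (0.04 log units; within the scatter), shows that hydrogen can stand in place of dimethoxymethyl on the double-bonded ring carbon next to the ring nitrogen without a readable change in the number. The earlier compounds shown here all kept dimethoxymethyl and varied only the aryl group, whereas this step removes 5 heavy atoms and 2 hydrogen-bond acceptors from the shared core, and with the 3-(trifluoromethyl)phenyl group held fixed, inhibition stays within the scatter of compound 3. Nothing on hand offers an explanation for this result.

Among these compounds, compound 4 is the only compound without dimethoxymethyl, so the finding rests on a single pair, and whether the same replacement leaves the number unchanged with the 3,4-dichlorophenyl group of compound 2 remains open. Also open, on these data alone, is how other groups at this ring carbon would compare with hydrogen and dimethoxymethyl, such as a methyl group, an aminomethyl group or a longer chain like ethoxymethyl.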